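Nitro Substitution Across Two Coumarin Ester Series

The source may hold more compounds than are shown below. What is called first, only, known or untested is meant among the compounds shown, and "the series" means these compounds.

Compound 1 `COc1cc2ccc(=O)oc2cc1OC(=O)c1c(C)noc1-c1ccccc1` and compound 3 `COc1cc2ccc(=O)oc2cc1OC(=O)c1c(-c2ccccc2)n[nH]c1C` share the same coumarin ester portion but carry different five-membered cores; the difference between the two cores is not broken down here. In a functional assay on Huh-7 cells (Homo sapiens) for inhibition, read by MTT assay, with a stated time of 48 h (on this read-out lower numbers stand for stronger inhibition and higher numbers for weaker inhibition), compound 1 gives > 25000 nM, which is a limit of the assay. Compound 3 likewise gives only > 25000 nM, again a limit of the assay. Compound 2 `COc1cc2ccc(=O)oc2cc1OC(=O)c1c(C)noc1-c1ccc([N+](=O)[O-])cc1` differs from compound 1 by nitro in place of hydrogen on an aromatic carbon, and in this assay compound 2 gives 8760 nM, so that an at least 2.8-fold lower number from compound 1 to compound 2 (0.45 log units; beyond the scatter). The size of that step is known only as a lower bound because the limit of > 25000 nM in this assay, at which 2 of the 3 values shown sit, is where compound 1 sits. Compound 4 `COc1cc2ccc(=O)oc2cc1OC(=O)c1c(-c2ccc([N+](=O)[O-])cc2)n[nH]c1C` has not yet been measured; it differs from compound 3 by nitro in place of hydrogen on an aromatic carbon, the same change as that from compound 1 to compound 2. The step expected for compound 4 is an at least 2.0-fold lower number from compound 3 to compound 4 (0.31 log units; beyond the scatter), an expectation resting on an at least 2.8-fold lower number from compound 1 to compound 2 (0.45 log units; beyond the scatter). The estimate for compound 4 in this assay is 12000 nM, expected to fall between 5000 nM and 25000 nM.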

Compound 4, half-maximal inhibitory concentration: > 25000 nM
Compound 4: a limit, no number (the forecaster's own chance of this, stated with the estimate: 35%); middle value at least 2.0-fold (0.31 log units) away from the limit.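

No step can be read from compound 3 to compound 4, because in this assay both compounds stand only at the same limit of the assay: the limit of > 25000 nM in this assay, at which 3 of the 4 values shown sit.

The compounds shown leave open whether the change from phenyl to 4-nitrophenyl lowers the number at all on the core of compound 3, as it does on the core of compound 1.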